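The source may hold more compounds than are shown below. What is called first, only, known or untested is meant among the compounds shown, and "the series" means these compounds.

Compound 1, `Nc1cccc(-c2cn3nc(Cc4ccc(Cl)cc4)sc3n2)c1`, gives 42000 nM in a functional assay on CCRF-CEM cells (Homo sapiens) for inhibition, read by cell counting, with a stated time of 3 days; on this read-out higher numbers stand for weaker inhibition and lower numbers for stronger inhibition. Compound 2, `COc1ccc(Cc2nn3cc(-c4cccc(N)c4)nc3s2)cc1`, gives only a limit of this assay, >= 250000 nM. Compound 3, `C=C(Br)C(=O)Nc1cccc(-c2cn3nc(-c4ccc(OC)cc4)sc3n2)c1`, gives 1200 nM.

Compound 2 and compound 1 share a core and differ in one place: chloro in place of methoxy on an aromatic carbon. This change brought an at least 5.9-fold lower number from compound 2 to compound 1 (0.77 log units; beyond the scatter). Its true size is not known, because of the limit of >= 250000 nM in this assay, at which 1 of the 3 values shown sits; the number for compound 2 is a limit and not a measured value, so the step could be larger than stated.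

Compound 3 carries a different core from compound 2; how the two cores differ is not broken down here. Of the two measured numbers, compound 3 has the lowest, and compound 1 lies a long way above it.

Compound 4, `C=C(Br)C(=O)Nc1cccc(-c2cn3nc(-c4ccc(Cl)cc4)sc3n2)c1`, has not yet been measured. It is made from compound 3 by the same change that turned compound 2 into compound 1: chloro in place of methoxy on an aromatic carbon. Both changes sit at the same place, on the same kind of ring and para to a large group, so this is the same change made on a different core.

Judged by what the change did between compound 2 and compound 1, compound 4 is expected to give a lower number than compound 3, with an expected step of a 2.4-fold lower number from compound 3 to compound 4 (0.38 log units; beyond the scatter). That expectation rests on the earlier step and on the fact that its size is only a lower bound. The value of compound 4 in this assay is estimated at 500 nM, expected to lie between 150 nM and 1500 nM.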

Compound 4, half-maximal inhibitory concentration: 3200 nM
For compound 4 the middle estimate is 6.4-fold (0.81 log units) below the measured one; the whole stated range lies below it.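

In this assay, putting chloro in place of methoxy on the aromatic ring gave a 2.7-fold higher number from compound 3 to compound 4 (0.43 log units; beyond the scatter), so the change moved the number in the opposite direction from the earlier step, and the two steps clearly disagree: the same change on two cores in this assay, an at least 5.9-fold lower number (0.77 log units; beyond the scatter) from compound 2 to compound 1 and a 2.7-fold higher number (0.43 log units; beyond the scatter) from compound 3 to compound 4, at least 15-fold (1.20 log units) apart, beyond the scatter of two such steps

This shows that the effect of going from 4-methoxyphenyl to 4-chlorophenyl did not carry from one core to the other in this series, so a result on one core was a poor guide to the result on the other. It does not show why the direction reversed, since the two pairs differ in their cores and four compounds cannot tell which part of a core matters, and the true size of the earlier step also remains unknown, since compound 2 gives only a limit: the limit of >= 250000 nM in this assay, at which 1 of the 4 values shown sits.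

As far as these compounds go, it remains open whether a smaller group such as fluoro, or a methyl group, at the same place on the ring would move the number in the same direction on both cores. From the compounds shown here alone, it is also open whether the reversal would persist if a plain acetyl amide or a free amine replaced the bromine-bearing amide of compound 3 and compound 4.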